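Aryl ether series: agonist maximal response, next step

This account rests on a few compounds, and the source may have more. Where it says the series, first, only, none or still open, it means among the compounds named here.

Compound 1 `CC(C)(C)OC(=O)N1CCC(O[C@H]2CC[C@H](Oc3ccc(S(C)(=O)=O)cc3)CC2)CC1` gives 115% in a functional assay on isolated protein for agonist activity at Glucose-dependent insulinotropic receptor (Homo sapiens), read by HTRF and cAMP accumulation; a higher number here means a larger maximal response, a lower number a smaller maximal response. Compound 2 `CC(C)(C)OC(=O)N1CCC(O[C@H]2CC[C@H](Oc3ccc(C#N)cc3)CC2)CC1` gives 116% in this assay.

For the measured compounds named here, compound 2 sits within the scatter of compound 1; the only measured step, a number 1 percentage points higher from compound 1 to compound 2 (within the scatter), is within the scatter.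

Compound 3 `CC(C)(C)OC(=O)N1CCC(O[C@H]2CC[C@H](Oc3ccc(S(C)(=O)=O)cn3)CC2)CC1` carries the change (5-(methylsulfonyl)pyridin-2-yl in place of 4-cyanophenyl on an oxygen on a saturated carbon). Going by the values given here, the step from compound 1 to compound 2 bears on it, since it exchanged the same two groups on the aromatic carbon and stayed within the scatter; no measured step covers the ring nitrogen. Compound 3 is therefore expected to show a step of a number 1 percentage points lower from compound 2 to compound 3 (within the scatter), none beyond the scatter. Compound 3 is estimated at 115%, between 100% and 130%.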

Compound 3, largest response reached (Emax), in percent of the reference or control that the assay uses: 111%
Compound 3: middle estimate off by 4 percentage points, on the high side, and the stated range covers the measured number.
By their numbers in this assay, from the lowest: compounds 3, 1 and 2 (each within the scatter of the next).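

In this assay, a ring with a hetero atom in place of the carbon-only ring gives a number 4 percentage points lower from compound 1 to compound 3 (within the scatter), and 5-(methylsulfonyl)pyridin-2-yl in place of 4-cyanophenyl gives a number 5 percentage points lower from compound 2 to compound 3 (within the scatter). On the oxygen on a saturated carbon, the pyridine ring therefore leaves the maximal response within the scatter of both phenyl compounds, with either the nitrile or the methylsulfonyl group. Nothing available explains this outcome.

On these data alone, it remains open whether an amine or a carboxylic acid on the aromatic ring would hold the response. The compounds shown also do not tell whether a ring nitrogen paired with the nitrile would behave the same way.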